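A Bulkier Acyl Group on a Shared Core

A few compounds are considered here, and "the series" means these few. Any claim that something is new, unique, unknown or untested is made for them only; others in the source may bear on it.

Of the compounds shown here, three have been tested in an assay on Sf9 cells for inhibition of inhibitor of nuclear factor kappa-B kinase subunit epsilon (Homo sapiens), read by ADP-Glo, with a stated time of 60 min; on this read-out lower numbers stand for stronger inhibition and higher numbers for weaker inhibition. Compound 1 `Cc1[nH]nc(N)c1-c1cccc(OC(F)(F)F)c1` returned only a limit, > 100000 nM. Compound 2 `Cc1c(N)n[nH]c1-c1ccc(Cl)c(Cl)c1` likewise gave only a limit, > 100000 nM. Compound 3 `CC(=O)n1nc(C)c(-c2ccc(Cl)c(Cl)c2)c1N` also stands at a limit, > 100000 nM, so no number marks its strength; every value shown sits at the limit of > 100000 nM in this assay, at which 3 of the 3 values shown sit. Compound 4 `Cc1nn(C(=O)C2CCCCC2)c(N)c1-c1ccc(Cl)c(Cl)c1` has not yet been measured. It differs from compound 3 by cyclohexyl in place of methyl on a carbonyl carbon, a cyclohexyl in place of methyl on a carbonyl carbon. For the measured compounds named here, no measured pair here differs in only one place, so there is no step to lean on. With every value at the limit, compound 4 is expected to show nothing beyond the scatter, a step of a number no higher from compound 3 to compound 4 (the limit leaves the size open). Compound 4 is therefore estimated at 100000 nM in this assay, within 30000 nM to 300000 nM.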

Compound 4, half-maximal inhibitory concentration: > 100000 nM
Compound 4: no number, only a limit (the forecaster's own chance of this, stated with the estimate: 85%); the middle value lies on the limit itself.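

Compound 3 and compound 4 both stand at a limit rather than a number, so no step can be read between them: the limit of > 100000 nM in this assay, at which 4 of the 4 values shown sit. The compounds shown leave open whether cyclohexyl in place of methyl on a carbonyl carbon changes inhibition at all.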